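Swapping the Octyl Group for Methoxy

The source may report more compounds than this note shows. Statements on the series, on what has been measured and on what is new or still open speak of the compounds shown alone.

Measured so far in a functional assay on HT-29 cells (Homo sapiens) for antiproliferative activity, read by sulforhodamine B assay, with a stated time of 72 h; a lower number here means a stronger inhibitor, a higher number a weaker inhibitor
compound 1 `CCCCCCCCc1ccc(CCC(CO)(CO)NC(C)=O)c2ccccc12` gives 36500 nM
compound 2 `CCCCCCCCCC(=O)NC(CO)(CO)CCc1ccc(CCCCCCCC)c2ccccc12` gives > 80000 nM (a limit)
compound 3 `CCCCCCCCc1ccc(CCC(CO)(CO)NC(=O)C(C)CC)c2ccccc12` gives 25600 nM

Among the measured compounds shown here, compound 1 and compound 3 hold the only two true numbers, and these lie within the usual scatter of each other. Compound 2 reports only a limit.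

Compound 4 `COc1ccc(CCC(CO)(CO)NC(C)=O)c2ccccc12` differs from compound 1 in one place: methoxy in place of octyl on an aromatic carbon. The methoxy group sits para to a large group on the aromatic ring.

For the measured compounds named here, no measured step tests this change, since all three measured compounds carry the octyl group. The available steps all lie at the carbonyl end of the molecule: a 1.4-fold lower number from compound 1 to compound 3 (0.15 log units; within the scatter), an at least 2.1-fold higher number from compound 1 to compound 2 (0.34 log units; beyond the scatter) and an at least 3.1-fold lower number from compound 2 to compound 3 (0.49 log units; beyond the scatter). They range from nothing beyond the scatter to a modest change, but they guide the size of a change elsewhere only loosely and say nothing firm about its direction. The new change removes far more of the group than the swap in a 1.4-fold lower number from compound 1 to compound 3 (0.15 log units; within the scatter), so a modest rise in the number is the cautious expectation, and a limit would be no surprise. The expected step is a 2.1-fold higher number from compound 1 to compound 4 (0.31 log units; beyond the scatter). For compound 4 the estimated value is 75000 nM, within an expected range of 35000 nM to 160000 nM.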

Compound 4, half-maximal inhibitory concentration: > 80000 nM
Compound 4: a limit, no number; the forecaster's own chance of this, stated with the estimate: 55%; at least 1.0-fold (0.02 log units) between middle value and limit.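

In this assay compound 4 gives > 80000 nM, which is a limit of the assay and not a number. Among the compounds shown here, this is the first change made on the aromatic carbon para to a large group, since every earlier step lay at the carbonyl end of the molecule, and methoxy in place of octyl gives an at least 2.1-fold higher number from compound 1 to compound 4 (0.34 log units; beyond the scatter), so this position does respond to what is placed on it, and in this swap the number rises beyond the scatter. The step has a lower bound only, and how far the number truly rises stays unread, with compound 4 sitting at the same limit as compound 2: the limit of > 80000 nM in this assay, at which 2 of the 4 values shown sit.

Going by these compounds, what remains open is how much of the octyl chain is needed, for example whether a butyl group or a longer decyl chain at this position would give a number close to that of compound 1. On these data alone, it is also open whether the rise follows the loss of the chain itself or the arrival of the oxygen, a question that an ethyl group or a plain hydrogen at the same carbon could help to separate.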